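From methoxy to a tert-butoxycarbonyl chain

The source may hold more compounds than are shown below. What is called first, only, known or untested is meant among the compounds shown, and "the series" means these compounds.

Compound 1 `CN1CCc2c(sc(NC(=O)Nc3ccc(Cl)cc3)c2C(N)=O)C1` gives 4700 nM
Compound 2 `NC(=O)c1c(NC(=O)Nc2ccc(Cl)cc2)sc2c1CCN(CC1CCC1)C2` gives 1360 nM
Compound 3 `COCCCN1CCc2c(sc(NC(=O)Nc3ccc(Cl)cc3)c2C(N)=O)C1` gives 2400 nM

In a functional assay (strain AB) with Danio rerio as the target, read by microscopy, with a stated time of 1 h (on this read-out higher numbers stand for an effect only at larger amounts of compound and lower numbers for an effect already at smaller amounts), compound 3 sits within the scatter of both other compounds, the two steps reaching it being a 2.0-fold lower number from compound 1 to compound 3 (0.29 log units; within the scatter) and a 1.8-fold higher number from compound 2 to compound 3 (0.25 log units; within the scatter) as measured. Compound 4 `CC(C)(C)OC(=O)CCCCCN1CCc2c(sc(NC(=O)Nc3ccc(Cl)cc3)c2C(N)=O)C1` differs from compound 3 in one place, where 2-(tert-butoxycarbonyl)ethyl takes the place of methoxy on a saturated chain carbon, three bonds along the chain from an amine nitrogen in a ring (counted: 2-(tert-butoxycarbonyl)ethyl in place of methoxy on a saturated chain carbon, three bonds along the chain from an amine nitrogen in a ring). All three measured steps change the group on this amine nitrogen. Only one lies beyond the scatter, a 3.5-fold lower number from compound 1 to compound 2 (0.54 log units; beyond the scatter) and it is modest. Among the measured compounds shown here, no measured compound carries tert-butoxycarbonyl, so none of these steps measures the change directly. In this assay no step beyond the scatter is therefore expected, and no direction is favoured. Expected is a 1.2-fold lower number from compound 3 to compound 4 (0.08 log units; within the scatter) as a step without firm direction. The estimated value for compound 4 is 2000 nM (expected range 700 nM to 5500 nM).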

Compound 4, half-maximal effective concentration: 620 nM
Compound 4: middle estimate off by 3.2-fold (0.51 log units), on the high side; measured number outside the range, below it.
By their numbers in this assay, from the lowest: compound 4; then compounds 2, 3 and 1 (each within the scatter of the next, the first and the last beyond it).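

Among the compounds shown here, compound 4 is the first compound in which replacing the methoxy end of the chain changes the number beyond the scatter in this assay, with a 3.9-fold lower number from compound 3 to compound 4 (0.59 log units; beyond the scatter) on the exchange for 2-(tert-butoxycarbonyl)ethyl. The same chain also stands apart from the cyclobutyl-bearing compound, with a 2.2-fold lower number from compound 2 to compound 4 (0.34 log units; beyond the scatter) on the change to 4-(tert-butoxycarbonyl)butyl. Measured against the smallest group on this amine nitrogen, it gives a 7.6-fold lower number from compound 1 to compound 4 (0.88 log units; beyond the scatter) and the largest step in the set, so this position accepts a long ester-bearing chain and the number still falls.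

As far as these compounds go, it remains open whether the ester or the chain length matters, which a free carboxylic acid, a plain alkyl chain or a terminal amine on the same chain could separate. Nothing available here explains the step.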